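Bis-arylidene cyclohexanone series: estimating compound 3

A few compounds are considered here, and "the series" means these few. Any claim that something is new, unique, unknown or untested is made for them only; others in the source may bear on it.

Compound 1 `COc1ccccc1/C=C1\CCC/C(=C\c2ccc(OC)c(OC)c2)C1=O` gives the lowest number of the two measured in a functional assay on HT-1080 cells (Homo sapiens) for cytotoxicity, read by MTT assay, with a stated time of 72 h (a higher number here means a weaker inhibitor, a lower number a stronger inhibitor), namely 8100 nM. Within the data shown here, compound 2 `COc1ccc(/C=C2\CCC/C(=C\c3ccc(OC)c(OC)c3)C2=O)c(OC)c1` gives 17100 nM in this assay, and the step of a 2.1-fold higher number from compound 1 to compound 2 (0.32 log units; beyond the scatter) is the one measured step of the set. Compound 3 `COc1ccc(/C=C2\CCC/C(=C\c3ccc(O)c(Cl)c3)C2=O)cc1OC` differs from compound 1 in 3-chloro-4-hydroxyphenyl in place of 2-methoxyphenyl on a double-bonded chain carbon bound to a double-bonded ring carbon. Among the measured compounds shown here, no measured step covers such an exchange; the step of a 2.1-fold higher number from compound 1 to compound 2 (0.32 log units; beyond the scatter) concerns a different change and gives little guidance here. Compound 3 is therefore expected to show a step of a 1.2-fold lower number from compound 1 to compound 3 (0.10 log units; within the scatter), within the scatter. The estimate for compound 3 is 6500 nM, within 2000 nM to 20000 nM.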

Compound 3, half-maximal inhibitory concentration: 7600 nM
Estimate against measurement, compound 3: 1.2-fold (0.07 log units) below, and the stated range covers the measured number.
By their numbers in this assay, from the lowest: compounds 3 and 1 (each within the scatter of the next); then compound 2.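

On a double-bonded chain carbon bound to a double-bonded ring carbon, 3-chloro-4-hydroxyphenyl and 2-methoxyphenyl cannot be told apart in this assay, with a 1.1-fold lower number from compound 1 to compound 3 (0.03 log units; within the scatter) for the exchange. The earlier methoxy step did not show that this position accepts an aryl group bearing chlorine and a hydrogen-bond donor with no change beyond the scatter. Nothing available offers a cause for this result.

Going by these compounds, whether each of the chlorine and the hydroxyl matters on its own remains open. Also open, on these data alone, is how an amine or a carboxylic acid on this aryl ring would read.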